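This account rests on a few compounds, and the source may have more. Where it says the series, first, only, none or still open, it means among the compounds named here.

Measured so far:
Compound 1 `NC(=S)Nc1cccc(OCCCCCOc2cccc(-c3ccccc3)c2)c1` — 13000 nM
Compound 2 `NC(=S)Nc1cccc(OCCCCCOc2cccc(Cc3ccccc3)c2)c1` — 13000 nM
Compound 3 `NC(=S)Nc1cccc(OCCCCCOc2cccc(Oc3ccccc3)c2)c1` — 18000 nM

All three were tested in an ADME assay on Ava5 cells (Homo sapiens) for cytotoxicity; on this read-out higher numbers stand for lower toxicity in this test and lower numbers for higher toxicity in this test. For the measured compounds named here, on these numbers compound 3 does not stand apart from the other two: a 1.4-fold higher number from compound 1 to compound 3 (0.14 log units; within the scatter) and a 1.4-fold higher number from compound 2 to compound 3 (0.14 log units; within the scatter), and between the first two compounds no change at the digits printed from compound 1 to compound 2 (within the scatter). The whole set therefore sits in one band of the same width as the scatter.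

Compound 4 `NC(=S)Nc1cccc(OCCCCCOc2cccc(Nc3ccccc3)c2)c1` has not yet been measured in this assay. It differs from compound 3 in one place: anilino in place of phenoxy on an aromatic carbon. Going by the values given here, the steps that bear on this change are the three swaps at the same aromatic carbon already seen, phenyl to benzyl, phenyl to phenoxy and benzyl to phenoxy, none of which moved the number beyond the scatter. On that basis compound 4 is expected to stay in the same band as compound 3, and the expected step of a 1.2-fold lower number from compound 3 to compound 4 (0.08 log units; within the scatter) is one within the scatter. The estimate for compound 4 in this assay is 15000 nM, with a range from 7000 nM to 32000 nM.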

Compound 4, half-maximal cytotoxic concentration: 11000 nM
Beside the measured number, compound 4's estimate is 1.4-fold (0.13 log units) above it; the measured number falls inside the stated range.
By their numbers in this assay, from the lowest: compounds 4, 1, 2 and 3 (each within the scatter of the next).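

Anilino is the first group at this aromatic carbon to add a hydrogen-bond donor, which phenoxy does not have, and in this assay the swap gives a 1.6-fold lower number from compound 3 to compound 4 (0.21 log units; within the scatter). The other two comparisons agree, with a 1.2-fold lower number from compound 2 to compound 4 (0.07 log units; within the scatter) and a 1.2-fold lower number from compound 1 to compound 4 (0.07 log units; within the scatter), so all four groups at this position fall within the scatter of one another, and this set shows no dependence of the read-out on the presence of that donor. No supporting data bear on this result.

What the compounds shown leave open is whether this position stays as tolerant with a group of a different kind, such as a carboxylic acid or a primary amine. They also leave open whether the same holds with a longer chain in place of the pentyl-length link in the shared core.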